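The source may hold more compounds than are shown below. What is called first, only, known or untested is meant among the compounds shown, and "the series" means these compounds.

Measured compounds in an assay on isolated protein for inhibition of cathepsin S (Homo sapiens); on this read-out higher numbers stand for weaker inhibition and lower numbers for stronger inhibition:
Compound 1 `CCn1c(=O)n(C2CCN(CC(O)Cn3nc(-c4ccc(Cl)c(C)c4)c4c3CCN(C(C)=O)C4)CC2)c2ccccc21` gives 310 nM.
Compound 2 `CS(=O)(=O)N1CCc2c(c(-c3ccc(Cl)c(Cl)c3)nn2CCCN2CCC(n3c(O)nc4ccccc43)CC2)C1` gives 10 nM.
Compound 3 `CS(=O)(=O)N1CCc2c(c(-c3ccc(C(F)(F)F)cc3)nn2CCCN2CCC(n3c(O)nc4ccccc43)CC2)C1` gives 50 nM.

Among these three, compound 2 carries the lowest number in this assay. Its nearest neighbour is compound 3, reached by a single change on an aromatic carbon, where a 5.0-fold higher number from compound 2 to compound 3 (0.70 log units; beyond the scatter). Going by the values given here, compound 1 lies furthest away, but it differs from compound 2 in several places at once, so its value and that of compound 2 can only be set side by side; no step between them is computed.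

Compound 4 `Cn1c(=O)n(C2CCN(CCCn3nc(-c4ccc(Cl)c(Cl)c4)c4c3CCN(S(C)(=O)=O)C4)CC2)c2ccccc21` differs from compound 2 in one place: a group of 11 heavy atoms (8 carbon, 2 nitrogen, 1 oxygen; one five-membered aromatic ring with 2 hetero atoms, one six-membered aromatic ring of carbon only) in place of a group of 10 heavy atoms (7 carbon, 2 nitrogen, 1 oxygen; one five-membered aromatic ring with 2 hetero atoms, one six-membered aromatic ring of carbon only), on a saturated ring carbon. Among the compounds with values here, none of the measured steps touches this part of the molecule; the only computed step, from compound 2 to compound 3, concerns the aryl group on the aromatic carbon and says nothing about the group on the saturated ring carbon. Compound 1 carries a related group at that position, yet its other differences prevent any reading of that comparison. Within the data shown here, with no step bearing on the change, compound 4 is expected to stay close to compound 2, with a 1.5-fold higher number from compound 2 to compound 4 (0.18 log units; within the scatter) estimated to lie within or only just beyond the scatter. The estimate for compound 4 in this assay is 15 nM, expected between 5 nM and 50 nM.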

Compound 4, half-maximal inhibitory concentration: 50 nM
Estimate against measurement, compound 4: 3.3-fold (0.52 log units) below; the measured number falls inside the stated range.
By their numbers in this assay, from the lowest: compound 2; then compounds 3 and 4 (each within the scatter of the next); then compound 1.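

In this assay, going by these compounds alone, putting the entering group in place of 2-hydroxy-1H-benzimidazol-1-yl on the saturated ring carbon gives a 5.0-fold higher number from compound 2 to compound 4 (0.70 log units; beyond the scatter), the first reading at a position that no earlier step touched, and it shows that the number responds to a change here. The two groups contain the same kinds of aromatic ring, while the entering group differs in its count of heavy atoms, has a double bond outside aromatic rings, and has 0 hydrogen-bond donors against 1, and this single pair cannot tell which of these differences carries the step. Its size matches that of the change on the aromatic carbon, a 5.0-fold higher number from compound 2 to compound 3 (0.70 log units; beyond the scatter), so compound 2 loses as much at this position as it does in that aryl exchange.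

No measurement at hand accounts for the step at this position. On these data alone, it remains open how an amine or a carboxylic acid on this saturated ring carbon would fare, and whether the step would keep its size with the 4-(trifluoromethyl)phenyl group of compound 3 in place of the 3,4-dichlorophenyl group.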